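This account rests on a few compounds, and the source may have more. Where it says the series, first, only, none or still open, it means among the compounds named here.

Measured so far in a functional assay on Raji cells (Homo sapiens) for cytotoxicity, read by CCK-8 assay, with a stated time of 24 h; on this read-out higher numbers stand for weaker inhibition and lower numbers for stronger inhibition:
Compound 1 `C=CC(=O)N1C(=O)CC(c2ccc(C(F)(F)F)cc2)Sc2ccccc21` gives 47600 nM
Compound 2 `C=CC(=O)N1C(=O)CC(c2ccc(Cl)cc2)Sc2ccccc21` gives 18400 nM
Compound 3 `C=CC(=O)N1C(=O)CC(c2ccccc2C(F)(F)F)Sc2ccccc21` gives 50300 nM

Compound 2 holds the lowest number of the three, and compound 1 and compound 3 both lie above it by more than the scatter. Compound 4 `C=CC(=O)N1C(=O)CC(c2cccc(Cl)c2)Sc2ccccc21` has not yet been measured and differs from compound 2 in one place. The change is 3-chlorophenyl in place of 4-chlorophenyl on a saturated ring carbon and puts 3-chlorophenyl in place of 4-chlorophenyl on a saturated ring carbon, next to the ring sulfur.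

Among the compounds with values here, only one measured step offers a guide, and only indirectly. It is a 2.6-fold lower number from compound 1 to compound 2 (0.41 log units; beyond the scatter) and it is modest, but it exchanges one group for another, whereas compound 4 keeps the chloro. Within the data shown here, no measured step shows what happens when a chloro changes place. The values of compound 1 and compound 3, which both carry trifluoromethyl, lie within the scatter of each other. A small step is therefore expected in this assay, possibly none beyond the scatter, and slightly more likely towards a higher number, since compound 2 at 18400 nM is the lowest so far. The expected step is a 1.3-fold higher number from compound 2 to compound 4 (0.12 log units; within the scatter) as an estimate. For compound 4 the estimated value is 24000 nM with an expected range from 12000 nM to 45000 nM in this measurement.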

Compound 4, half-maximal inhibitory concentration: 47100 nM
Compound 4: middle estimate off by 2.0-fold (0.29 log units), on the low side, and the stated range ends below it.
By their numbers in this assay, from the lowest: compound 2; then compounds 4, 1 and 3 (each within the scatter of the next).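

In this assay, the place of the chloro on the phenyl group matters on its own: 3-chlorophenyl in place of 4-chlorophenyl on the saturated ring carbon, with the same atoms joined differently, gives a 2.6-fold higher number from compound 2 to compound 4 (0.41 log units; beyond the scatter) with nothing else altered. Within the data shown here, the one earlier step exchanged one group for another, so this is the first view of a change of place alone, and its printed size matches that of the exchange of trifluoromethyl for chloro, a 2.6-fold lower number from compound 1 to compound 2 (0.41 log units; beyond the scatter) on this read-out. No measured evidence bears on why the place of the chloro counts here.

With trifluoromethyl the picture is not the same, as compound 1 gives 47600 nM and compound 3 gives 50300 nM in this assay, two values within the scatter of each other, so the compounds shown do not settle whether the sensitivity to place extends beyond chloro. They also leave open how a methoxy group, an amine or a carboxylic acid on the phenyl ring would behave at these places.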